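The source may hold more compounds than are shown below. What is called first, only, known or untested is meant among the compounds shown, and "the series" means these compounds.

Compound 1 `CC(=O)Nc1ccc(NC(=O)c2cc(Cl)ccc2O)c(Cl)c1` gives "not determined" (no result reported) as its entry
Compound 2 `O=C(Nc1ccc(NCc2ccc(Br)cc2)cc1Cl)c1cc(Cl)ccc1O` gives 40900 nM as its entry

Going by the values given here, both compounds belong to an ADME assay on A549 cells (Homo sapiens) for cytotoxicity, read by resazurin assay, with a stated time of 48 h (on this read-out higher numbers stand for lower toxicity in this test and lower numbers for higher toxicity in this test), and compound 2, with 40900 nM as its result, holds the only number, so it cannot yet be ranked against another compound. Compound 3 `O=C(Nc1ccc(NCc2cc(F)cc(Cl)c2)cc1Cl)c1cc(Cl)ccc1O` has not yet been measured. It differs from compound 2 at one place (3-chloro-5-fluorophenyl in place of 4-bromophenyl on a saturated chain carbon bound to a nitrogen on an aromatic ring). Among the compounds with values here, no measured step offers guidance, so no change beyond the scatter is expected in this assay for this exchange. The expected shift (a 1.2-fold lower number from compound 2 to compound 3 (0.07 log units; within the scatter)) is therefore small. Compound 3 is estimated at 35000 nM with an expected range of 12000 nM to 90000 nM for its result.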

Compound 3, half-maximal cytotoxic concentration: 11100 nM
Estimate against measurement, compound 3: 3.2-fold (0.50 log units) above, outside the stated range (below it).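

Going by these compounds alone, the first step at this position, 3-chloro-5-fluorophenyl in place of 4-bromophenyl on a saturated chain carbon bound to a nitrogen on an aromatic ring, gives a 3.7-fold lower number from compound 2 to compound 3 (0.57 log units; beyond the scatter) in this assay. This shows that the read-out responds to this exchange, moving towards higher toxicity in this test. Nothing available accounts for the shift.

Within the data shown here, the single step does not separate the loss of bromine from the arrival of chlorine and fluorine. On these data alone, how an unsubstituted phenyl, a pyridine or a longer chain would read at this place remains open.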